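The source may hold more compounds than are shown below. What is called first, only, known or untested is meant among the compounds shown, and "the series" means these compounds.

Of the compounds shown here, three have been measured in an ADME assay on MT4 cells (Homo sapiens) for cytotoxicity, read by MTT assay; on this read-out higher numbers stand for lower toxicity in this test and lower numbers for higher toxicity in this test. Compound 1, `Cc1ccccc1NC(=S)OCCc1ccccn1`, gives > 100000 nM, which is a limit of the assay rather than a number. Compound 2, `S=C(Nc1ccccc1Cl)OCCc1ccccn1`, gives > 100000 nM in this assay, again only a limit. Compound 3, `Cc1ccc(NC(=S)OCCc2ccccc2)cc1`, gives > 100000 nM in this assay, also a limit. Every measured value therefore stands at the limit of > 100000 nM in this assay, at which 3 of the 3 values shown sit. Compound 2 differs from compound 1 by chloro in place of methyl on an aromatic carbon, and the step that the two limits leave unreadable from compound 1 to compound 2 is left unreadable by the two limits. The difference between the core of compound 1 and the core of compound 3 is not broken down here.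

Compound 4, `S=C(Nc1ccc(Cl)cc1)OCCc1ccccc1`, has not yet been measured. It differs from compound 3 by chloro in place of methyl on an aromatic carbon. This is the same kind of change as that from compound 1 to compound 2, but not the same: in compound 2 the chloro sits ortho to a large group, whereas in compound 4 it sits para to a large group. Compound 4 is expected to give 150000 nM in this assay, most likely again as a limit only, because all three measured compounds sit at the limit of > 100000 nM in this assay, at which 3 of the 3 values shown sit. The expected step is a step that the limit leaves unreadable from compound 3 to compound 4, resting on the same evidence. The estimate spans from 50000 nM to 500000 nM.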

Compound 4, half-maximal cytotoxic concentration: > 100000 nM
Compound 4 was reported as a limit (the forecaster's own chance of this, stated with the estimate: 85%); the middle value lies beyond the limit too.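

Compound 3 and compound 4 are both reported only as limits of the assay, so no size can be read for the change from methyl to chloro between them. The compounds shown leave open how far past the limit each one lies, and whether any of these changes shifts the read-out at all, since every value stands at one point: the limit of > 100000 nM in this assay, at which 4 of the 4 values shown sit.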